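Removing the chloro group from compound 1 in the series

The source may report more compounds than this note shows. Statements on the series, on what has been measured and on what is new or still open speak of the compounds shown alone.

Compound 1 `Nc1cc(-c2cnc3[nH]cc(-c4ccncc4)c3c2)ccc1Cl` is the reference here. In a functional assay on MCF7 cells (Homo sapiens) for cytotoxicity, read by MTT assay, with a stated time of 48 h (a higher number here means a weaker inhibitor, a lower number a stronger inhibitor), compound 1 gives 12000 nM, the highest of the two numbers shown. The nearest number belongs to compound 2 `Nc1cc(NS(=O)(=O)c2ccccc2)cc(-c2cnc3[nH]cc(-c4ccncc4)c3c2)c1`, which in this assay gives 8800 nM, within the scatter of compound 1. Compound 3 `CC(=O)Nc1cc(N)cc(-c2cnc3[nH]cc(-c4ccncc4)c3c2)c1` in this assay reaches only a limit, > 30000 nM, and no number is known for it. Among the compounds with values here, the one measured step, an at least 3.4-fold higher number from compound 2 to compound 3 (0.53 log units; beyond the scatter), is therefore bounded only on one side, as the limit of > 30000 nM in this assay, at which 1 of the 3 values shown sits, shows.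

Compound 4 `Nc1cccc(-c2cnc3[nH]cc(-c4ccncc4)c3c2)c1` is the next member to be placed. Its change from compound 1 is hydrogen in place of chloro on an aromatic carbon. Within the data shown here, no measured step touches this chloro group; the only measured step, an at least 3.4-fold higher number from compound 2 to compound 3 (0.53 log units; beyond the scatter), concerns the substituent on a different nitrogen and says nothing about the substituent beside the amino group. With nothing measured that bears directly on the change, no step beyond the scatter is expected in this assay in either direction. Compound 4 is therefore expected to give about 15000 nM in this assay, with a range of 6000 nM to 40000 nM. The expected step is a 1.3-fold higher number from compound 1 to compound 4 (0.10 log units; within the scatter).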

Compound 4, half-maximal inhibitory concentration: 2300 nM
Compound 4: middle estimate off by 6.5-fold (0.81 log units), on the high side; the measured number lies below the stated range.
By their numbers in this assay, from the lowest: compound 4; then compounds 2 and 1 (each within the scatter of the next). At a limit, above all of these: compound 3.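

In this assay the chloro group, ortho to an amino group, now has a measured reading: the step is a 5.2-fold lower number from compound 1 to compound 4 (0.72 log units; beyond the scatter) and shows that this place is sensitive to the substituent it carries. Compound 4 also gives the other two substituents a hydrogen reference, with a 3.8-fold lower number from compound 2 to compound 4 (0.58 log units; beyond the scatter) for (phenylsulfonyl)amino and an at least 13-fold lower number from compound 3 to compound 4 (1.11 log units; beyond the scatter) for acetamido, so all three groups shown go with a higher number than hydrogen and compound 4 is the strongest of the four. The acetamido step is bounded on one side only, as the value of compound 3 is a limit of the assay and not a number: the limit of > 30000 nM in this assay, at which 1 of the 4 values shown sits.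

The compounds shown leave open whether a smaller or different group such as fluoro, methyl or methoxy in the place of the chloro group would also raise the number, or whether only chloro does so. They also leave open how much the amino group itself contributes, since no compound shown carries a hydroxy group or a dimethylamino group in its place.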